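The compounds below may be only part of what the source reports. "The series", "measured", "known", "first", "only" and "open" are said of these compounds alone.

Among the compounds with values here, compound 2 `COc1ccc(/C=C/C(=O)/C=C/C2=C(C)CCCC2(C)C)cc1` gives 23900 nM in a functional assay on IMR-32 cells (Homo sapiens) for cytotoxicity, read by sulforhodamine B assay, with a stated time of 48 h (on this read-out higher numbers stand for weaker inhibition and lower numbers for stronger inhibition), the lower of the two numbers measured so far; the nearest is compound 1 `CC1=C(/C=C/C(=O)/C=C/c2ccc(Cl)cc2)C(C)(C)CCC1`, which in this assay gives 52300 nM. Within the data shown here, the only step between measured compounds, a 2.2-fold lower number from compound 1 to compound 2 (0.34 log units; beyond the scatter), is a modest move on putting methoxy in place of chloro on an aromatic carbon. Compound 3 `CC1=C(/C=C/C(=O)/C=C/c2ccc([N+](=O)[O-])cc2)C(C)(C)CCC1` differs from compound 2 by nitro in place of methoxy on an aromatic carbon. Among the measured compounds shown here, no measured compound carries a nitro, so that single step is the only guide, and it shows a swap at this aromatic carbon shifting the number only modestly. A shift of similar or smaller size is therefore expected in this assay, with the direction undecided. For compound 3 the expected step is a 1.3-fold higher number from compound 2 to compound 3 (0.10 log units; within the scatter). Compound 3 is thus estimated at 30000 nM, with a range from 10000 nM to 90000 nM.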

Compound 3, half-maximal inhibitory concentration: 3200 nM
Compound 3: the middle estimate sits 9.4-fold (0.97 log units) above what was measured; the whole stated range lies above it.
By their numbers in this assay, from the lowest: compound 3; then compound 2; then compound 1.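

In this assay, the group on this aromatic carbon, para to a large group, can move the number much further than the first swap indicated: the change to nitro gives a 7.5-fold lower number from compound 2 to compound 3 (0.87 log units; beyond the scatter) when it replaces methoxy, and a 16-fold lower number from compound 1 to compound 3 (1.21 log units; beyond the scatter) when it replaces chloro. Both steps lie beyond the scatter, so within these three compounds nitro stands apart from both earlier groups, and the position is more sensitive to its substituent than the step between methoxy and chloro showed. Nothing available explains why nitro stands apart from methoxy and chloro.

From the compounds shown here alone, whether an amine or a carboxylic acid on the same carbon would track with nitro or with the other two groups remains open. Also open, going by these compounds, is whether the low number of compound 3 carries over to other cell lines.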